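Ortho Substituent Swaps on a Diacylhydrazine Ecdysone Agonist

The source may report more compounds than this note shows. Statements on the series, on what has been measured and on what is new or still open speak of the compounds shown alone.

Compound 1 `CC(C)(C)N(NC(=O)c1ccccc1)C(=O)c1ccccc1F`: 309 nM
Compound 2 `CC(C)(C)N(NC(=O)c1ccccc1)C(=O)c1ccccc1Cl`: 75.9 nM
Compound 3 `CC(C)(C)N(NC(=O)c1ccccc1)C(=O)c1ccccc1I`: 105 nM

Three compounds share one core and differ only in the group on an aromatic carbon of one ring. In an assay on cells for agonist activity at ecdysone receptor (Bombyx mori), read by a luciferase reporter, with a stated time of 24 h (a lower number here means that less compound is needed, a higher number that more compound is needed for the effect), compound 1 gives 309 nM, compound 2 gives 75.9 nM and compound 3 gives 105 nM. Compound 3 therefore sits second of the three numbers: its step from compound 2 is small, a 1.4-fold higher number from compound 2 to compound 3 (0.14 log units; within the scatter), while its step from compound 1 is clear, a 2.9-fold lower number from compound 1 to compound 3 (0.47 log units; beyond the scatter).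

The next compound, compound 4 `CC(C)(C)N(NC(=O)c1ccccc1)C(=O)c1ccccc1C(F)(F)F`, changes one thing: trifluoromethyl in place of iodo on an aromatic carbon.

Going by the values given here, none of the measured steps involves a trifluoromethyl group, so the guide is indirect. Moving from fluoro to a larger halogen helped, a 4.1-fold lower number from compound 1 to compound 2 (0.61 log units; beyond the scatter) and a 2.9-fold lower number from compound 1 to compound 3 (0.47 log units; beyond the scatter), whereas chloro against iodo made little difference, a 1.4-fold higher number from compound 2 to compound 3 (0.14 log units; within the scatter). The two larger groups behaved alike, and trifluoromethyl is another group of similar bulk, so the expected step in this assay is small, either way, and may stay within the scatter.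

Compound 4 is therefore estimated at 130 nM, with a range of 50 nM to 350 nM, corresponding to an expected step of a 1.2-fold higher number from compound 3 to compound 4 (0.09 log units; within the scatter).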

Compound 4, half-maximal effective concentration: 631 nM
For compound 4 the middle estimate is 4.9-fold (0.69 log units) below the measured one; the whole stated range lies below it.
By their numbers in this assay, from the lowest: compounds 2 and 3 (each within the scatter of the next); then compound 1; then compound 4.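

In this assay, going by these compounds alone, this position turns out to be far less forgiving than the halogens suggested: chloro and iodo could stand in for each other, yet trifluoromethyl, the only one of the four groups that is not a single halogen atom, gives a 6.0-fold higher number from compound 3 to compound 4 (0.78 log units; beyond the scatter) and an 8.3-fold higher number from compound 2 to compound 4 (0.92 log units; beyond the scatter) in the steps from those two compounds. The earlier gain over fluoro also does not carry over, since replacing fluoro with trifluoromethyl reverses its direction, with a 2.0-fold higher number from compound 1 to compound 4 (0.31 log units; beyond the scatter), which makes compound 4 the least potent of the four in this assay. Nothing available bears on the reason for this loss.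

The compounds shown leave open whether the loss belongs to trifluoromethyl alone or would appear with any group of several atoms at this position, a question that a methyl, a methoxy or a nitrile group in the same place could help to settle. Bromo, the halogen missing from the series, would also show whether the close match between chloro and iodo holds for a further single atom.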